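A few compounds are considered here, and "the series" means these few. Any claim that something is new, unique, unknown or untested is made for them only; others in the source may bear on it.

Of the compounds shown here, three sharing one core have been measured in an assay on Sf9 cells for inhibition of protein deacetylase HDAC6 (Homo sapiens), read by fluorescence, with a stated time of 40 min, tested at 100 nM; a higher number here means more inhibition at the concentration tested (going by the name of the read-out), a lower number less inhibition. Compound 1 `CCc1ccc(-n2nc(-c3ccccc3)nc2CNc2ccc(C(=O)NO)cc2)cc1` gives 38.3%. Compound 2 `Cc1ccc(-c2nc(CNc3ccc(C(=O)NO)cc3)n(-c3ccccc3)n2)cc1` gives 62.2%. Compound 3 `Cc1ccc(-n2nc(-c3ccccc3)nc2CNc2ccc(C(=O)NO)cc2)cc1` gives 60.7%. Compound 2 thus has the largest of the three numbers, but its gap to compound 3 lies within the scatter of the assay, so the two cannot be told apart; only its gap to compound 1 lies beyond the scatter. Among the compounds with values here, the one single-point step among the measured compounds, a number 22.4 percentage points higher from compound 1 to compound 3 (beyond the scatter), concerns a hydrogen in place of a methyl on a saturated chain carbon bound to an aromatic carbon, a different place from the change now considered.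

Compound 4 `O=C(NO)c1ccc(NCc2nc(-c3ccc(Cl)c(Cl)c3)nn2-c2ccccc2)cc1` differs from compound 2 by 3,4-dichlorophenyl in place of 4-methylphenyl on an aromatic carbon. Within the data shown here, no measured step touches this position, so there is no direct precedent for the size or direction of the change in this assay. Among the measured compounds shown here, the only guidance is that compound 2 and compound 3, which carry the same groups arranged differently, sit within the scatter of each other. With nothing pointing one way, the expected step of a number 2.2 percentage points lower from compound 2 to compound 4 (within the scatter) is taken as none beyond the scatter. The estimate for compound 4 in this assay is therefore 60%, with a range from 38% to 80%.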

Compound 4, a percentage reported as inhibition, at one concentration (the size of the read-out at that concentration, not a potency): 34.5%
Estimate against measurement, compound 4: 25.5 percentage points above; the measured number lies below the stated range.
By their numbers in this assay, from the lowest: compounds 4 and 1 (each within the scatter of the next); then compounds 3 and 2 (each within the scatter of the next).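

In this assay, the group on the aromatic carbon between two ring nitrogen atoms proves to matter: a number 27.7 percentage points lower from compound 2 to compound 4 (beyond the scatter), with 3,4-dichlorophenyl in place of 4-methylphenyl. Within the data shown here, this is the first measured step at this position, and it shows that the number can respond to what the phenyl ring carries, even though both groups have one six-membered aromatic ring of carbon only, no hydrogen-bond donors or acceptors and no net charge. Nothing in the available data bears on the reason for this drop.

On these data alone, two things change together in this step, since the methyl group leaves and two chlorine atoms enter, so it remains open whether the loss comes with the missing methyl, with chlorine as such, or only with the pair of chlorine atoms. A phenyl ring carrying a single chlorine atom, or one carrying a methoxy group, would help to separate these possibilities and to show how far the number at this position can move in either direction.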